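Replacing Nitro with Cyano on the Aryl Triazole

A few compounds are considered here, and "the series" means these few. Any claim that something is new, unique, unknown or untested is made for them only; others in the source may bear on it.

Measured so far:
compound 1, `CCOC(=O)c1sc(NC(=O)Cn2cc(-c3ccc(F)cc3)nn2)nc1C`: 660 nM
compound 2, `CCOC(=O)c1sc(NC(=O)Cn2cc(-c3ccc([N+](=O)[O-])cc3)nn2)nc1C`: 1840 nM

Among the measured compounds shown here, in a functional assay on BMDM cells (Mus musculus, strain C57BL/6) for inhibition, with a stated time of 2 days (on this read-out lower numbers stand for stronger inhibition and higher numbers for weaker inhibition), compound 2 stands at the highest of the two numbers, and the only measured step, a 2.8-fold higher number from compound 1 to compound 2 (0.45 log units; beyond the scatter), separates it from compound 1. Compound 3, `CCOC(=O)c1sc(NC(=O)Cn2cc(-c3ccc(C#N)cc3)nn2)nc1C`, differs from compound 2 by cyano in place of nitro on an aromatic carbon. For the measured compounds named here, no measured step exchanges nitro for cyano; the one known step, a 2.8-fold higher number from compound 1 to compound 2 (0.45 log units; beyond the scatter), bears on it only indirectly, showing that the group at this place shifts the number modestly. Compound 3 is therefore expected to show a 1.7-fold lower number from compound 2 to compound 3 (0.22 log units; within the scatter), a modest downward step. Compound 3 is estimated at 1100 nM, within 400 nM to 3000 nM.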

Compound 3, half-maximal inhibitory concentration: 310 nM
The estimate for compound 3 lay 3.5-fold (0.55 log units) above the measured number; the measured number lies below the stated range.
By their numbers in this assay, from the lowest: compound 3; then compound 1; then compound 2.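

In this assay, cyano in place of nitro gives a 5.9-fold lower number from compound 2 to compound 3 (0.77 log units; beyond the scatter) and cyano in place of fluoro gives a 2.1-fold lower number from compound 1 to compound 3 (0.33 log units; beyond the scatter). The group at this place on the aromatic ring can therefore move the number down as well as up, and compound 3 now has the lowest number of the three. Nothing at hand accounts for these steps.

Only fluoro, nitro and cyano are shown at this place, so it remains open how an amine or a carboxylic acid there would read.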